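From compound 3 to the acetyl compound 4

The source may hold more compounds than are shown below. What is called first, only, known or untested is meant among the compounds shown, and "the series" means these compounds.

In an ADME assay (liver) for metabolic stability, with Liver microsome (Rattus norvegicus) as the target, using microsomes and NADPH, with a stated time of 30 min (a higher number here means faster removal of the compound, a lower number slower removal), compound 3 (`CC#CCC(O)(c1ccc(N2CCN(S(=O)(=O)c3ccc(N)nc3)C[C@@H]2C#CC)cc1)C(F)(F)F`) gives 115 mL.min-1.g-1, the lower of the two numbers in the series. Compound 1 (`CC#C[C@H]1CN(S(=O)(=O)c2ccc(N)nc2)CCN1c1ccc(S(=O)(=NC)C(F)(F)F)cc1`) gives 257 mL.min-1.g-1. Compound 2 (`CC#C[C@H]1CN(S(=O)(=O)c2ccc(N)nc2)CCN1c1ccc(S(=O)(=O)Nc2ccccc2)cc1`) gives only a limit of the assay, > 399 mL.min-1.g-1. Compound 4 (`CC#C[C@H]1CN(S(=O)(=O)c2ccc(N)nc2)CCN1c1ccc(C(C)=O)cc1`) differs from compound 3 by a group of 3 heavy atoms (2 carbon, 1 oxygen; no ring) in place of a group of 10 heavy atoms (6 carbon, 1 oxygen, 3 fluorine; no ring), on an aromatic carbon, with acetyl para to a large group. Two measured steps at this place bear on it: a 2.2-fold lower number from compound 1 to compound 3 (0.35 log units; beyond the scatter) and an at least 3.4-fold lower number from compound 2 to compound 3 (0.54 log units; beyond the scatter). Both end at compound 3, and neither involves acetyl, so the read-across is loose. A step of similar size toward a higher number is expected, a 2.1-fold higher number from compound 3 to compound 4 (0.32 log units; beyond the scatter). Compound 4 is estimated at 240 mL.min-1.g-1, with an expected range of 110 mL.min-1.g-1 to 420 mL.min-1.g-1.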

Compound 4, intrinsic clearance in microsomes: 249 mL.min-1.g-1
Beside the measured number, compound 4's estimate is 1.0-fold (0.02 log units) below it; low and high end bracket the measured number.
By their numbers in this assay, from the lowest: compound 3; then compounds 4 and 1 (each within the scatter of the next). At a limit, above all of these: compound 2.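

In this assay, acetyl on this aromatic carbon separates from the larger group of compound 3: a 2.2-fold higher number from compound 3 to compound 4 (0.34 log units; beyond the scatter). Acetyl and the group of 8 heavy atoms it replaces, which differ in heavy-atom count and in carrying sulfur and fluorine, cannot be told apart: a 1.0-fold lower number from compound 1 to compound 4 (0.01 log units; within the scatter). Acetyl in place of phenylsulfamoyl gives a step whose floor lies within the scatter: an at least 1.6-fold lower number from compound 2 to compound 4 (0.20 log units; that floor lies within the scatter). That step cannot be read, since compound 2 stands at a limit of the assay: the limit of > 399 mL.min-1.g-1 in this assay, at which 1 of the 4 values shown sits.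

Which part of the group in compound 3 goes with its lower number stays open. From the compounds shown here alone, how a nitrile or a carboxylic acid at this place would compare also stays open.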